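The source may hold more compounds than are shown below. What is called first, only, known or untested is meant among the compounds shown, and "the series" means these compounds.

In an assay on isolated protein for inhibition of alpha-galactosidase (Coffea arabica), read by spectrophotometry, tested at 100 uM (on this read-out lower numbers stand for less inhibition and higher numbers for more inhibition at the one concentration tested (going by the name of the read-out)), compound 1, with the structure `NC[C@@H]1NC[C@H](O)[C@H](O)[C@H]1O`, gives 13%. Compound 2, with the structure `NC[C@H]1NC[C@H](O)[C@H](O)[C@H]1O`, is reported in this assay as "not active" (no number reported), without a number attached to that result. The two compounds share every atom and bond, and the fact that compounds 1 and 2 differ only in the configuration as drawn is the only thing that sets them apart, so for compound 2 the inhibition in this assay rests on that reported verdict alone, with no figure to place it more precisely.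

Compound 3, with the structure `NC[C@H]1NC[C@H](O)[C@@H](O)[C@H]1O`, is the next compound in this series. Its change from compound 2 is the two compounds have the same atoms and bonds and differ only in configuration as drawn: 1 of 4 stereo elements differ; a stereocentre at a saturated ring carbon is drawn S in compound 2 and R in compound 3. Within the data shown here, nothing has yet been measured for compound 3, and no step between measured compounds is available to anchor an expectation for it. On what the numbers of compound 1 and compound 2 show, both low in this assay, compound 3 is expected to remain in the low range, with no step beyond the scatter in either direction being predicted. Compound 3 is estimated at 10% in this assay, with a range from 0% to 30%.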

Compound 3, a percentage reported as inhibition, at one concentration (the size of the read-out at that concentration, not a potency): >= 20%
Compound 3: only a limit was reported; the forecaster's own chance of this, stated with the estimate: 30%; middle value at least 10 percentage points away from the limit.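

In this assay compound 3 gives >= 20%, which is a limit of the assay and not a number. Compound 2 stands as "not active" (no number reported), and the step to compound 3 cannot be read as a size, yet these two verdicts now show that the configuration at this one saturated ring carbon, drawn S in compound 2 and R in compound 3, is the only thing separating them: the fact that compounds 2 and 3 differ only in the configuration as drawn. The other comparison gives a number at least 7 percentage points higher from compound 1 to compound 3 (that floor lies within the scatter), and with two stereocentres changed at once, it sets no order between those two compounds.

What the compounds shown leave open is how far the actual inhibition of compound 3 lies from its limit, and whether the same change of configuration would give a similar result at the other stereocentres of the shared core. They also leave open whether the stereochemical difference would carry over if a carboxylic acid or a longer chain stood in place of the amine.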